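Variation at one ring position in exchanger inhibitors

The source may hold more compounds than are shown below. What is called first, only, known or untested is meant among the compounds shown, and "the series" means these compounds.

compound 1 `Cc1cc(C2CCCCC2)c(S(C)(=O)=O)cc1C(=O)N=C(N)N`: 22 nM
compound 2 `Cc1cc(-c2ccccc2)c(S(C)(=O)=O)cc1C(=O)N=C(N)N`: 19 nM
compound 3 `Cc1cc(-c2ccco2)c(S(C)(=O)=O)cc1C(=O)N=C(N)N`: 16 nM

In a functional assay for inhibition of sodium/hydrogen exchanger (Oryctolagus cuniculus) (on this read-out higher numbers stand for weaker inhibition and lower numbers for stronger inhibition), compound 3 gives the lowest of the three numbers, yet the steps of a 1.4-fold lower number from compound 1 to compound 3 (0.14 log units; within the scatter) and a 1.2-fold lower number from compound 2 to compound 3 (0.07 log units; within the scatter) both lie within the scatter, as does a 1.2-fold lower number from compound 1 to compound 2 (0.06 log units; within the scatter), so the three compounds are not separated. Compound 4 `CSc1cc(C)c(C(=O)N=C(N)N)cc1S(C)(=O)=O` carries the change (methylsulfanyl in place of furan-2-yl on an aromatic carbon). All three measured steps concern this same position and none moved the number beyond the scatter, which argues for a small step; the entering group, with no ring, is unlike anything measured, so the estimate is loose and leans toward a slightly higher number, a 1.9-fold higher number from compound 3 to compound 4 (0.27 log units; within the scatter). Compound 4 is therefore expected at 30 nM, within 10 nM to 90 nM.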

Compound 4, half-maximal inhibitory concentration: 6 nM
Beside the measured number, compound 4's estimate is 5.0-fold (0.70 log units) above it; measured number outside the range, below it.
By their numbers in this assay, from the lowest: compound 4; then compounds 3, 2 and 1 (each within the scatter of the next).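

In this assay this position proves able to move the number: methylsulfanyl gives a 2.7-fold lower number from compound 3 to compound 4 (0.43 log units; beyond the scatter) and a 3.2-fold lower number from compound 2 to compound 4 (0.50 log units; beyond the scatter) and a 3.7-fold lower number from compound 1 to compound 4 (0.56 log units; beyond the scatter), whereas the three ring-bearing groups stayed unseparated. A group with no ring, ortho to a methylsulfonyl group, therefore goes with the lowest number of the four. No available data bear on the reason for this shift.

From the compounds shown here alone, whether the sulfur or the absence of a ring goes with the lower number stays open. A methoxy group or a longer alkylsulfanyl chain at this position would bear on that question.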